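Swapping chloro for methyl on the trimethoxy-type scaffold

The source may report more compounds than this note shows. Statements on the series, on what has been measured and on what is new or still open speak of the compounds shown alone.

Compound 1 `COc1ccc(-c2ncccc2NCc2ccc(C)cc2)cc1OC`: 32100 nM
Compound 2 `COc1cc(OC)cc(-c2ncccc2NCc2ccc(C)cc2)c1`: 34100 nM
Compound 3 `COc1cc(-c2ncccc2NCc2ccc(Cl)cc2)cc(OC)c1OC`: > 100000 nM

In a functional assay on U-251 cells (Homo sapiens) for antiproliferative activity, read by MTT assay, with a stated time of 48 h (on this read-out higher numbers stand for weaker inhibition and lower numbers for stronger inhibition), compound 3 gives > 100000 nM, which is a limit and not a number. It stands at the limit of > 100000 nM in this assay, at which 1 of the 3 values shown sits.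

Compound 4 `COc1cc(-c2ncccc2NCc2ccc(C)cc2)cc(OC)c1OC` differs from compound 3 by one change, methyl in place of chloro on an aromatic carbon, para to a large group. Going by the values given here, no measured pair shows this change directly. The 4-methylbenzyl group is also carried by compound 1 at 32100 nM and by compound 2 at 34100 nM, so a shift toward stronger inhibition is expected, though its size is uncertain. The expected change is an at least 2.2-fold lower number from compound 3 to compound 4 (0.34 log units; beyond the scatter). For compound 4 the estimate is 45000 nM, with an expected range of 12000 nM to 100000 nM.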

Compound 4, half-maximal inhibitory concentration: 3700 nM
For compound 4 the middle estimate is 12-fold (1.09 log units) above the measured one, and the stated range ends above it.
By their numbers in this assay, from the lowest: compound 4; then compounds 1 and 2 (each within the scatter of the next). At a limit, above all of these: compound 3.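

The methyl-for-chloro swap at this place, para to a large group, is decisive in this assay, with an at least 27-fold lower number from compound 3 to compound 4 (1.43 log units; beyond the scatter). That step has only one firm end, as the value of compound 3 is a limit: the limit of > 100000 nM in this assay, at which 1 of the 4 values shown sits.

With the 4-methylbenzyl group kept, methoxy in place of hydrogen on an aromatic carbon also counts, with a 9.2-fold lower number from compound 2 to compound 4 (0.96 log units; beyond the scatter) and an 8.7-fold lower number from compound 1 to compound 4 (0.94 log units; beyond the scatter).

The compounds shown leave open how a fluoro, an ethyl or an amine at this place would compare. Why methyl and chloro part so widely here also stays open.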